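Removing the carboxy group from the pyridyl substituent

This account rests on a few compounds, and the source may have more. Where it says the series, first, only, none or still open, it means among the compounds named here.

Going by the values given here, compound 3 `O=C(O)c1cc(-c2cnc(C(=O)CCc3ccc(-c4ccccc4)cc3)o2)ccn1` gives 50 nM in an assay for inhibition of Fatty-acid amide hydrolase 1 (Rattus norvegicus) (a lower number here means a stronger inhibitor, a higher number a weaker inhibitor), the highest of the three numbers measured so far. Compound 1 `O=C(CCc1ccc(-c2ccccc2)cc1)c1ncc(-c2ccncc2)o1` gives 2.3 nM and compound 2 `COC(=O)c1ccc(-c2cnc(C(=O)CCc3ccc(-c4ccccc4)cc3)o2)nc1` gives 2.2 nM; these two lie within the scatter of each other. The change to compound 4 `O=C(CCc1ccc(-c2ccccc2)cc1)c1ncc(-c2cccnc2)o1` is pyridin-3-yl in place of 2-carboxypyridin-4-yl on an aromatic carbon. Among the compounds with values here, two measured steps bear on it: a 22-fold higher number from compound 1 to compound 3 (1.34 log units; beyond the scatter) and a 23-fold higher number from compound 2 to compound 3 (1.36 log units; beyond the scatter) both show that the carboxy-bearing compound 3 stands far above the other two members. Within the data shown here, the step to compound 4 removes that carboxy group and also moves from pyridin-4-yl to pyridin-3-yl; no measured pair isolates the second part of this change, so its own contribution is unknown. The expectation is therefore a large drop, roughly undoing the rise seen on going to compound 3, with some added uncertainty for the ring nitrogen shift. Compound 4 is expected to give 3 nM, within a range of 1 nM to 12 nM. The expected step is thus a 17-fold lower number from compound 3 to compound 4 (1.22 log units; beyond the scatter).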

Compound 4, inhibition constant: 1.1 nM
Compound 4: the middle estimate sits 2.7-fold (0.44 log units) above what was measured; low and high end bracket the measured number.
By their numbers in this assay, from the lowest: compounds 4, 2 and 1 (each within the scatter of the next, the first and the last beyond it); then compound 3.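

Taking out the carboxy-bearing group at this aromatic carbon, next to the ring oxygen, gives a 45-fold lower number from compound 3 to compound 4 (1.66 log units; beyond the scatter) and leaves compound 3 as the only outlier among the four in this assay. The ring nitrogen's location now has a direct reading: pyridin-3-yl in place of pyridin-4-yl gives a 2.1-fold lower number from compound 1 to compound 4 (0.32 log units; beyond the scatter) and so a modest step, whereas pyridin-3-yl in place of 5-(methoxycarbonyl)pyridin-2-yl gives a 2.0-fold lower number from compound 2 to compound 4 (0.30 log units; within the scatter) and so no separation between those two groups. Nothing measured here speaks to the reason for any of these steps.

Open, on these data alone, is whether a carboxylic acid on the pyridin-3-yl ring would carry the same penalty as in compound 3, and whether a primary amide or an amine there would sit with compound 3 or with the other three. A plain phenyl ring at this position would show whether a ring nitrogen is needed at all.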